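The source may hold more compounds than are shown below. What is called first, only, known or untested is meant among the compounds shown, and "the series" means these compounds.

Within the data shown here, in a functional assay on MCF7 cells (Homo sapiens) for antiproliferative activity, read by MTT assay, with a stated time of 48 h (on this read-out higher numbers stand for weaker inhibition and lower numbers for stronger inhibition), compound 1 `O=C(/C=C/c1cn(S(=O)(=O)c2ccc([N+](=O)[O-])cc2)c2ccccc12)c1ccncc1` gives 14500 nM; "dose-dependent effect" (no number reported) (2 entries) as its only number. Compound 2 `CCCS(=O)(=O)n1cc(/C=C/C(=O)c2ccncc2)c2ccccc21` stands at 52400 nM in this assay and this is the higher of the two numbers, meaning weaker inhibition. Compound 3 `O=C(/C=C/c1cn(S(=O)(=O)c2ccc(Cl)cc2)c2ccccc12)c1ccncc1` carries 4-chlorophenyl in place of propyl on a sulfonyl sulfur. Among the measured compounds shown here, no measured step isolates this change. Compound 1 also carries an aromatic ring on the sulfonyl sulfur and gives 14500 nM; "dose-dependent effect" (no number reported) (2 entries) in this assay so stronger inhibition than in compound 2, beyond the scatter, is expected. The expected change is a 3.3-fold lower number from compound 2 to compound 3 (0.52 log units; beyond the scatter) in size. The estimate for compound 3 is 16000 nM with an expected range from 5000 nM to 50000 nM on this read-out.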

Compound 3, half-maximal inhibitory concentration: 37500 nM
Compound 3: the middle estimate sits 2.3-fold (0.37 log units) below what was measured, and the stated range covers the measured number.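

In this assay, 4-chlorophenyl in place of propyl on a sulfonyl sulfur gives a 1.4-fold lower number from compound 2 to compound 3 (0.15 log units; within the scatter), so at this place a six-membered aromatic ring and a short chain are not told apart by this read-out. The data at hand give no cause for this outcome.

Still open, on these data alone, is what a longer chain in place of propyl would give on the same sulfonyl sulfur. An amine or a carboxylic acid on the aromatic ring also remains untested among the compounds shown, so the reach of this place is unknown.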